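The source may report more compounds than this note shows. Statements on the series, on what has been measured and on what is new or still open speak of the compounds shown alone.

Measured in a functional assay on PC-3 cells (Homo sapiens) for cytotoxicity, read by MTT assay, with a stated time of 72 h; on this read-out lower numbers stand for stronger inhibition and higher numbers for weaker inhibition:
- compound 1 `CNC(=O)c1cc(Oc2ccc(C3=NNC(c4ccc(Cl)cc4Cl)C3)cc2)ccn1`: 7300 nM
- compound 2 `CNC(=O)c1cc(Oc2ccc(C3=NNC(c4cccc(Br)c4)C3)cc2)ccn1`: 3540 nM
- compound 3 `CNC(=O)c1cc(Oc2ccc(C3=NNC(c4cc(OC)c(OC)c(OC)c4)C3)cc2)ccn1`: 28300 nM

Compound 2 has the lowest number of the three in this assay, at 3540 nM. Compound 4 `CNC(=O)c1cc(Oc2ccc(C3=NNC(c4ccc(C#N)cc4)C3)cc2)ccn1` has not yet been measured. The change is 4-cyanophenyl in place of 3-bromophenyl on a saturated ring carbon of the five-membered non-aromatic ring.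

One measured step involves a change at this same carbon and bears directly on the comparison: a 2.1-fold lower number from compound 1 to compound 2 (0.31 log units; beyond the scatter). That step is modest. The values also show a wider span, since compound 3 stands at 28300 nM against 3540 nM for compound 2. Among the compounds with values here, no measured compound carries a nitrile, so the data do not fix the direction firmly. Compound 2, at 3540 nM, is already the lowest of the three, so a higher number seems the more likely outcome of the exchange, on the scale of the modest step rather than the full span.

The expected change is a 2.1-fold higher number from compound 2 to compound 4 (0.33 log units; beyond the scatter), a modest step to a higher number. For compound 4 the estimated value is 7500 nM, with an expected range of 2500 nM to 22000 nM.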

Compound 4, half-maximal inhibitory concentration: 9910 nM
Compound 4: the middle estimate sits 1.3-fold (0.12 log units) below what was measured; low and high end bracket the measured number.
By their numbers in this assay, from the lowest: compound 2; then compounds 1 and 4 (each within the scatter of the next); then compound 3.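

In this assay, this saturated ring carbon shows that the 4-cyanophenyl group does not match the 3-bromophenyl group, with a 2.8-fold higher number from compound 2 to compound 4 (0.45 log units; beyond the scatter), so the nitrile joins the 2,4-dichlorophenyl and 3,4,5-trimethoxyphenyl groups on the side of higher numbers and compound 2 keeps the lowest number of the four. The nitrile and the dichloro pattern cannot be told apart here, with a 1.4-fold higher number from compound 1 to compound 4 (0.13 log units; within the scatter), so two quite different substituted phenyl groups read alike at this carbon, while compound 3 stays apart at 28300 nM. Nothing available gives a cause for these differences.

The step from compound 2 to compound 4 exchanges the substituent and its place on the phenyl ring together, and a 3-cyanophenyl or 4-bromophenyl group at this carbon would separate those two changes. Also open, on these data alone, is how this read-out responds to a carboxylic acid or an aminomethyl group on the same phenyl ring, and whether the unsubstituted phenyl group reads above or below the 3-bromophenyl group.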